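This account rests on a few compounds, and the source may have more. Where it says the series, first, only, none or still open, it means among the compounds named here.

Two measured compounds share one core and differ only in the chain that hangs from the amide-type nitrogen of that core. Compound 1, `Cc1cc(C(=O)Nc2ccc(Cl)cc2)ccc1N(CC(=O)N1CCOCC1)C(=O)Nc1ccc(Cl)cc1`, carries a (morpholin-4-yl)carbonyl group on that chain; in an ADME assay on microsomes from liver (Mus musculus) for metabolic stability (on this read-out higher numbers stand for a longer-lived compound and lower numbers for a shorter-lived compound), compound 1 gives 0.472 h. Compound 2, `Cc1cc(C(=O)Nc2ccc(Cl)cc2)ccc1N(CCN1CCCC1)C(=O)Nc1ccc(Cl)cc1`, carries a (pyrrolidin-1-yl)methyl group instead, and in this assay compound 2 gives 0.597 h. Going by the values given here, the single measured step, a 1.3-fold higher number from compound 1 to compound 2 (0.10 log units; within the scatter), is small, so on these two numbers compound 2 and compound 1 cannot be told apart, and compound 2 is simply the one with the higher of the two readings as they stand.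

Compound 3, `Cc1cc(C(=O)Nc2ccc(Cl)cc2)ccc1N(CCN1CCOCC1=O)C(=O)Nc1ccc(Cl)cc1`, comes from compound 2 by the change (3-oxomorpholin-4-yl in place of pyrrolidin-1-yl on a saturated chain carbon, two bonds along the chain from an amide-type nitrogen). Among the compounds with values here, only one step bears on this change, and it concerns a different group in the same region of the molecule. That step lay within the scatter, so no movement beyond the scatter is expected here either; the expected step of a 1.2-fold lower number from compound 2 to compound 3 (0.08 log units; within the scatter) is taken to be small. For compound 3 the estimate in this assay is 0.5 h, with a range from 0.25 h to 1 h.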

Compound 3, half-life: 0.148 h
For compound 3 the middle estimate is 3.4-fold (0.53 log units) above the measured one; the whole stated range lies above it.
By their numbers in this assay, from the lowest: compound 3; then compounds 1 and 2 (each within the scatter of the next).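

In this assay, this position proves able to move the read-out: 3-oxomorpholin-4-yl in place of pyrrolidin-1-yl, on a saturated chain carbon two bonds along the chain from an amide-type nitrogen, gives a 4.0-fold lower number from compound 2 to compound 3 (0.61 log units; beyond the scatter), a modest step beyond the scatter. The change from (morpholin-4-yl)carbonyl to (3-oxomorpholin-4-yl)methyl gives a 3.2-fold lower number from compound 1 to compound 3 (0.50 log units; beyond the scatter), also modest and beyond the scatter, so the earlier pair, whose two numbers could not be told apart, did not show the full range of this chain. No measurement shown here gives a reason for the lower number of compound 3.

The step from compound 2 to compound 3 alters the ring size, the ring atoms and the carbonyl all at once, and the compounds shown leave open which of these differences goes with the shorter half-life. A 2-(morpholin-4-yl)ethyl group, which has the six-membered ring with its oxygen but no ring carbonyl, or a 2-(2-oxopyrrolidin-1-yl)ethyl group, which has the five-membered ring with a ring carbonyl, would pull these differences apart.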